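From 2,4-dimethoxyphenyl to furan-3-yl: what to expect

This account rests on a few compounds, and the source may have more. Where it says the series, first, only, none or still open, it means among the compounds named here.

- Compound 1 `CC(=O)c1ccc2c(c1)nc(-c1ccoc1)n2C1CCCCC1`: > 100000 nM, a limit of the assay and not a number
- Compound 2 `COc1ccc(-c2nc3cc(/C(C)=N/NC(N)=O)ccc3n2C2CCCCC2)cc1`: 54000 nM
- Compound 3 `COc1ccc(-c2nc3cc(/C(C)=N/NC(N)=O)ccc3n2C2CCCCC2)c(OC)c1`: 36000 nM

In an ADME assay on MDBK cells (Bos taurus) for cytotoxicity, read by MTT assay, with a stated time of 96 h (on this read-out lower numbers stand for higher toxicity in this test and higher numbers for lower toxicity in this test), compound 3 gives 36000 nM, which cannot be told apart from compound 2 at 54000 nM. Only these two compounds have actual numbers to compare.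

Compound 4 `C/C(=N\NC(N)=O)c1ccc2c(c1)nc(-c1ccoc1)n2C1CCCCC1` carries furan-3-yl in place of 2,4-dimethoxyphenyl on an aromatic carbon, next to the ring atom that bears a cyclohexyl group: furan-3-yl in place of 2,4-dimethoxyphenyl on an aromatic carbon.

Going by the values given here, only one measured step comes close to this change. It is a 1.5-fold lower number from compound 2 to compound 3 (0.18 log units; within the scatter), made by putting methoxy in place of hydrogen on an aromatic carbon. That step is small, so it gives no reason to expect a large one here, although it does not cover the exchange of a whole ring.

The furan-3-yl group also sits on compound 1, whose reading is only a limit, > 100000 nM. That compound differs elsewhere too, so it is a weak guide, but it tilts the expectation towards a higher number.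

The expected change is a 1.8-fold higher number from compound 3 to compound 4 (0.26 log units; within the scatter), a modest step. For compound 4 the estimated value is 65000 nM, with an expected range from 30000 nM to 100000 nM.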

Compound 4, half-maximal cytotoxic concentration: > 100000 nM
Compound 4 was reported as a limit; the forecaster's own chance of this, stated with the estimate: 40%; middle value at least 1.5-fold (0.18 log units) away from the limit.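

In this assay, furan-3-yl in place of 2,4-dimethoxyphenyl gives an at least 2.7-fold higher number from compound 3 to compound 4 (0.44 log units; beyond the scatter), so this exchange of a whole ring on the aromatic carbon bearing it moves the reading past the scatter, which the earlier addition of a methoxy group on the phenyl ring did not do. Measured against the 4-methoxyphenyl group, the same kind of exchange gives an at least 1.8-fold higher number from compound 2 to compound 4 (0.26 log units; that floor lies within the scatter), so that comparison sets only a floor and does not by itself show a change beyond the scatter. Compound 4 and compound 1 each stand at a limit of the assay and not at a number, which leaves the step between them unreadable: the limit of > 100000 nM in this assay, at which 2 of the 4 values shown sit.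

This exchange replaces a six-membered aromatic ring of carbon only with a smaller five-membered aromatic ring that holds an oxygen, and the compounds shown do not separate the effect of ring size from that of ring type. Also open, as far as these compounds go, is how a simple amine or a short alkyl chain such as ethyl would read on this carbon, between the two ring nitrogen atoms.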